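Cytotoxicity of three quinolone esters and an untested analogue

The source may report more compounds than this note shows. Statements on the series, on what has been measured and on what is new or still open speak of the compounds shown alone.

Compound 1 `CCOC(=O)c1c(-c2cccc(-c3ccccc3)c2)[nH]c2cc(OC)c(OC)cc2c1=O`, compound 2 `CCOC(=O)c1c(-c2cccc(OC)c2)[nH]c2cc(OC)c(OC)cc2c1=O` and compound 3 `CCOC(=O)c1c(-c2cccc(-c3ccccc3)c2)[nH]c2cc(OC)c(Cl)cc2c1=O` were tested in an ADME assay on HEK293 cells (Homo sapiens) for cytotoxicity, read by luminescence, with a stated time of 72 h; a higher number here means that more compound is needed for the effect, a lower number that less compound is needed. Compound 1 gives > 22000 nM, a limit of the assay rather than a number. Compound 2 likewise gives > 22000 nM, a limit. Compound 3 gives > 22000 nM, also a limit. The change methoxy in place of phenyl on an aromatic carbon therefore produces a step that the two limits leave unreadable from compound 1 to compound 2, and the core difference chloro in place of methoxy on an aromatic carbon produces a step that the two limits leave unreadable from compound 1 to compound 3. Compound 4 `CCOC(=O)c1c(-c2cccc(OC)c2)[nH]c2cc(OC)c(Cl)cc2c1=O` is not yet measured; it differs from compound 3 by methoxy in place of phenyl on an aromatic carbon, the same change seen from compound 1 to compound 2. Because (the limit of > 22000 nM in this assay, at which 3 of the 3 values shown sit), the step that the limit leaves unreadable from compound 3 to compound 4 is expected to be unreadable as well. Compound 4 is estimated at 40000 nM in this assay, most likely reported again as a limit.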

Compound 4, half-maximal effective concentration: > 22000 nM
Compound 4: a limit, no number (the forecaster's own chance of this, stated with the estimate: 85%); the middle value lies beyond the limit too.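

Compound 4 gives a limit, as do compound 2 and compound 3, so no step among these compounds can be read: the limit of > 22000 nM in this assay, at which 4 of the 4 values shown sit. As far as these compounds go, whether methoxy in place of phenyl or chloro in place of methoxy changes the reading in this assay at all remains open.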